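Working notes: fluoro to chloro in the series

A few compounds are considered here, and "the series" means these few. Any claim that something is new, unique, unknown or untested is made for them only; others in the source may bear on it.

Measured in an ADME assay on WI-38 cells (Homo sapiens) for cytotoxicity, read by MTT assay, with a stated time of 72 h; on this read-out higher numbers stand for weaker inhibition and lower numbers for stronger inhibition:
- compound 1 `O=C(CCc1cccc2c1B(O)OC2)Nc1cccc(Br)c1`: 20000 nM
- compound 2 `O=C(CCc1cccc2c1B(O)OC2)Nc1cccc(I)c1`: 71000 nM
- compound 3 `O=C(CCc1cccc2c1B(O)OC2)Nc1cccc(-c2cccc(F)c2)c1`: 37000 nM

Compound 3 stands within the scatter of both other compounds, as shown by a 1.9-fold higher number from compound 1 to compound 3 (0.27 log units; within the scatter) and by a 1.9-fold lower number from compound 2 to compound 3 (0.28 log units; within the scatter). The next compound to be measured in this assay is compound 4 `O=C(CCc1cccc2c1B(O)OC2)Nc1cccc(-c2cccc(Cl)c2)c1`, which has chloro in place of fluoro on an aromatic carbon, meta to a large group (chloro in place of fluoro on an aromatic carbon). Among the compounds with values here, no measured compound carries chloro, so no step tests this change directly.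

Within the data shown here, the closest evidence is the one exchange of a single halogen for another, a 3.6-fold higher number from compound 1 to compound 2 (0.55 log units; beyond the scatter). That modest step involves a different pair of groups, and its size can only be carried over loosely. The larger exchanges give a 1.9-fold higher number from compound 1 to compound 3 (0.27 log units; within the scatter) and a 1.9-fold lower number from compound 2 to compound 3 (0.28 log units; within the scatter), so even the replacement of a halogen by a whole 3-fluorophenyl group stays small here. A step beyond the scatter is therefore not expected, and no direction is favoured. The expected step is a 1.1-fold lower number from compound 3 to compound 4 (0.02 log units; within the scatter). For compound 4 the estimated value is 35000 nM, with an expected range of 15000 nM to 80000 nM.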

Compound 4, half-maximal inhibitory concentration: 58000 nM
Compound 4: the middle estimate sits 1.7-fold (0.22 log units) below what was measured, and the stated range covers the measured number.
By their numbers in this assay, from the lowest: compounds 1, 3, 4 and 2 (each within the scatter of the next, the first and the last beyond it).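

In this assay, within the data shown here, chloro in place of fluoro on an aromatic carbon of a six-membered aromatic ring of carbon only, meta to a large group, gives a 1.6-fold higher number from compound 3 to compound 4 (0.20 log units; within the scatter) and so leaves this halogen exchange inside the scatter, the first direct reading of this change. The 3-chlorophenyl group nevertheless gives a 2.9-fold higher number from compound 1 to compound 4 (0.46 log units; beyond the scatter), a modest step beyond the scatter, whereas the 3-fluorophenyl group gave only a 1.9-fold higher number from compound 1 to compound 3 (0.27 log units; within the scatter) against the same bromo compound, and against iodo the 3-chlorophenyl group gives a 1.2-fold lower number from compound 2 to compound 4 (0.09 log units; within the scatter), which lies within the scatter. No supporting measurement bears on this result, so the reading stops at the numbers themselves.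

The compounds shown leave open whether this place tolerates groups other than halogens, such as an amine, a carboxylic acid or a methoxy group in place of chloro, and whether any of these would give a step beyond the scatter. Also open, on these data alone, is how chloro alone would read in place of bromo or iodo, and how a longer chain would read in place of the one that carries the amide.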